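The source may report more compounds than this note shows. Statements on the series, on what has been measured and on what is new or still open speak of the compounds shown alone.

Three compounds share one core. Compound 1 `CC[C@H](C)[C@H](NC(=O)c1cccc(Cn2ccnc2)c1)C(=O)Nc1nccs1` carries a five-membered heteroaromatic amide on its carboxyl side; in an assay on HEK293 cells for displacement of a labelled ligand from Type-2 angiotensin II receptor (Homo sapiens) (on this read-out lower numbers stand for stronger inhibition and higher numbers for weaker inhibition), compound 1 gives 42000 nM, a weak result. Compound 2 `CCCCNC(=O)[C@@H](NC(=O)c1cccc(Cn2ccnc2)c1)[C@@H](C)CC` replaces that ring with a butyl amide, but in this assay compound 2 gives "not determined" (no result reported), so its standing cannot be placed against compound 1. Compound 3 `CCCCS(=O)(=O)NNC(=O)[C@@H](NC(=O)c1cccc(Cn2ccnc2)c1)[C@@H](C)CC` is the unmeasured partner of compound 2; the change is (butylsulfonyl)amino in place of butyl on an amide-type nitrogen. Within the data shown here, with no measured pair to show what this change does, the size of the step in this assay for compound 3 is uncertain; a move toward stronger inhibition by more than the usual scatter seems plausible, though a result beyond the scatter in either direction cannot be excluded. On this basis compound 3 is estimated at 5000 nM, with a range from 500 nM to 50000 nM.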

Compound 3, inhibition constant: > 100000 nM
Compound 3 ended at the assay's limit; the forecaster's own chance of this, stated with the estimate: 25%; at least 20-fold (1.30 log units) between middle value and limit.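

In this assay, putting (butylsulfonyl)amino in place of 1,3-thiazol-2-yl on the amide-type nitrogen gives an at least 2.3-fold higher number from compound 1 to compound 3 (0.37 log units; beyond the scatter), so on this nitrogen the new group reads weaker than the ring, by more than the usual scatter. The result for compound 3 is a limit of the assay and not a number, so the step has a minimum size but no known full size: the limit of > 100000 nM in this assay, at which 1 of the 3 values shown sits. Compound 2 has no reported result, so the step from it to compound 3 cannot be read, and the change from butyl to (butylsulfonyl)amino remains unmeasured.

On these data alone, whether a shorter group such as (methylsulfonyl)amino, or a phenyl ring, would read stronger at this nitrogen remains open. Also open, as far as these compounds go, is how far the inhibition constant of compound 3 actually lies beyond its limit.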